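One Carbon Less: From Compound 1 to Compound 3

The source may report more compounds than this note shows. Statements on the series, on what has been measured and on what is new or still open speak of the compounds shown alone.

Measured so far:
Compound 1, `CCOc1ccc2cc(C(=O)/C=C/c3c(/C=C/c4ccc(OC)cc4)cc(OC)cc3OC)c(=O)oc2c1`: 48100 nM
Compound 2, `COc1ccc(/C=C/c2cc(OC)cc(OC)c2/C=C/C(=O)c2cc3cc(C)ccc3oc2=O)cc1`: 5090 nM

Both numbers come from an assay on isolated protein for inhibition of Amine oxidase [flavin-containing] B (Homo sapiens), read by fluorescence, with a stated time of 15 min; a higher number here means a weaker inhibitor, a lower number a stronger inhibitor. Compound 1 gives the higher of the two, and compound 2 sits well below it, by a gap beyond the usual scatter; the two compounds differ in more than one place, so no single change can be tied to that gap.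

Compound 3, `COc1ccc(/C=C/c2cc(OC)cc(OC)c2/C=C/C(=O)c2cc3ccc(OC)cc3oc2=O)cc1`, has not been measured. It differs from compound 1 by hydrogen in place of methyl on a saturated chain carbon bound to an oxygen on an aromatic ring, or ethoxy to methoxy. Going by the values given here, no measured pair shows this change on its own, so the direction can only be guessed. The expected step from compound 1 to compound 3 is a 1.9-fold lower number from compound 1 to compound 3 (0.28 log units; within the scatter), a small gain that may not exceed the scatter. Compound 3 is therefore estimated at 25000 nM, in the range 6000 nM to 100000 nM.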

Compound 3, half-maximal inhibitory concentration: 4200 nM
Compound 3: middle estimate off by 6.0-fold (0.77 log units), on the high side, outside the stated range (below it).
By their numbers in this assay, from the lowest: compounds 3 and 2 (each within the scatter of the next); then compound 1.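

Trimming ethoxy to methoxy gives, in this assay, an 11-fold lower number from compound 1 to compound 3 (1.06 log units; beyond the scatter), and this is the first pair in which a single change can be read on its own. It shows that this position is sensitive: the loss of one carbon, with no ring, charge, hydrogen-bond donor or hydrogen-bond acceptor leaving, is enough to produce a large step. Nothing at hand bears on why so small a change has so large an effect.

Still open, as far as these compounds go, is whether a longer chain such as propoxy would raise the number further, and how a hydroxyl or an amine in place of the methoxy would compare. Also open, from the compounds shown here alone, is whether the same trimming would give a step of this size on a different core.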